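The source may hold more compounds than are shown below. What is called first, only, known or untested is meant among the compounds shown, and "the series" means these compounds.

Compound 1, `COc1cc(-n2ncnc2-c2cccc([N+](=O)[O-])c2)cc(OC)c1OC`. In a functional assay on Jurkat cells (Homo sapiens) for antiproliferative activity, read by MTT assay, with a stated time of 72 h (on this read-out higher numbers stand for weaker inhibition and lower numbers for stronger inhibition), compound 1 gives > 10000 nM, which is a limit of the assay and not a number.
Compound 2, `COc1cc(-c2ncnn2-c2ccc(Cl)c(Cl)c2)cc(OC)c1OC`. In this assay compound 2 gives > 10000 nM, again a limit and not a number.

Compound 2 therefore stands at the ceiling of what this assay reports; no number is known for it, only that it lies past the limit. Going by the values given here, the one further value shown, for compound 1, is a limit of the same kind, so that (the limit of > 10000 nM in this assay, at which 2 of the 2 values shown sit), and nothing measured here separates the two compounds. Among the compounds with values here, no step between measured compounds is available that would show how a single change shifts the read-out.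

Compound 3, `COc1cc(-c2ncnn2-c2ccc(Cl)cc2)cc(OC)c1OC`, has not yet been measured. It differs from compound 2 in one place: hydrogen in place of chloro on an aromatic carbon, which one bond further out reads as a 3,4-dichlorophenyl becoming a 4-chlorophenyl. With compound 2 at the limit, the step from compound 2 to compound 3 in this assay is expected to be none beyond the scatter, in no stated direction, and the estimate a step that the limit leaves unreadable from compound 2 to compound 3 reflects that expectation. Compound 3 is expected to give about 20000 nM, in the range 5000 nM to 80000 nM, most likely reported again only as a limit.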

Compound 3, half-maximal inhibitory concentration: > 10000 nM
Compound 3 ended at the assay's limit; the forecaster's own chance of this, stated with the estimate: 85%; the middle value lies beyond the limit too.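

Compound 3 sits at a limit of this assay, as compound 2 does, so no step can be read for the change from 3,4-dichlorophenyl to 4-chlorophenyl: the limit of > 10000 nM in this assay, at which 3 of the 3 values shown sit. The compounds shown leave open how far past that limit each one lies, and which change, if any, would give a readable value.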